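Shifting the Indole Attachment on an Amine Nitrogen

The source may report more compounds than this note shows. Statements on the series, on what has been measured and on what is new or still open speak of the compounds shown alone.

Three measured compounds share a core in which an amine nitrogen is joined to a double-bonded chain carbon. In a functional assay on BT-474 cells (Homo sapiens) for cytotoxicity, read by MTT assay, with a stated time of 48 h (on this read-out higher numbers stand for weaker inhibition and lower numbers for stronger inhibition), compound 1 `COc1ccc(-c2nc(C(=O)/C=C\Nc3ccc4[nH]ccc4c3)c3ccccn23)cc1` gives 13000 nM. Compound 2 `COc1ccc(N/C=C\C(=O)c2nc(-c3ccc(C(F)(F)F)cc3)n3ccccc23)cc1OC` gives > 30000 nM, which is a limit of the assay rather than a number. Compound 3 `O=C(/C=C\Nc1ccc2cc[nH]c2c1)c1nc(-c2ccc(C(F)(F)F)cc2)n2ccccc12` gives > 30000 nM, again only a limit. For the measured compounds named here, the one measured step, a step that the two limits leave unreadable from compound 2 to compound 3, starts and ends at that limit, so its size cannot be read; two of the three values shown sit at the limit of > 30000 nM in this assay, at which 2 of the 3 values shown sit. Compound 4 `O=C(/C=C\Nc1ccc2[nH]ccc2c1)c1nc(-c2ccc(C(F)(F)F)cc2)n2ccccc12` differs from compound 3 only in the change (1H-indol-5-yl in place of 1H-indol-6-yl on an amine nitrogen), the same atoms joined differently. Going by the values given here, no measured step bears on this change, and compound 1, which carries the same 1H-indol-5-yl group on a different core, shows only a weak number on its own. Since compound 3 stands at the limit, the expected step of a number no higher from compound 3 to compound 4 (the limit leaves the size open) can only be estimated loosely, with a real chance that compound 4 again returns only a limit. Compound 4 is expected near 30000 nM, within 10000 nM to 100000 nM.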

Compound 4, half-maximal inhibitory concentration: 5190 nM
The estimate for compound 4 lay 5.8-fold (0.76 log units) above the measured number; measured number below the stated range.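

In this assay, the change from 1H-indol-6-yl to 1H-indol-5-yl on the amine nitrogen gives an at least 5.7-fold lower number from compound 3 to compound 4 (0.76 log units; beyond the scatter), so the way the same atoms are joined is enough to turn a limit into a real number. Placing 1H-indol-5-yl where 3,4-dimethoxyphenyl stood gives an at least 5.7-fold lower number from compound 2 to compound 4 (0.76 log units; beyond the scatter). With 1H-indol-5-yl held fixed, trifluoromethyl in place of methoxy on an aromatic carbon gives a 2.5-fold lower number from compound 1 to compound 4 (0.40 log units; beyond the scatter), so both compounds carrying this indole return real numbers.

On these data alone, the first two steps give only a minimum size, and the step from compound 2 to compound 3 cannot be read: the limit of > 30000 nM in this assay, at which 2 of the 4 values shown sit. Also open is how a 1H-indol-4-yl group or a plain phenyl on the same amine nitrogen would read.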